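The source may report more compounds than this note shows. Statements on the series, on what has been measured and on what is new or still open speak of the compounds shown alone.

Measured in a toxicity assay on NIH3T3 cells (Mus musculus) for cytotoxicity, read by resazurin assay; on this read-out lower numbers stand for an effect already at smaller amounts and higher numbers for an effect only at larger amounts of compound:

- Compound 1 `Clc1ccc(NCc2cncn2Cc2ccc(-c3ccccc3)cc2)cc1-c1ccccc1`: > 1000 nM, a limit
- Compound 2 `COC(=O)c1ccc(NCc2cncn2Cc2ccccc2Cl)cc1-c1ccccc1`: 10000 nM
- Compound 3 `c1ccc(-c2ccc(Cn3cncc3CNc3ccc(-c4ccccc4)c(-c4ccccc4)c3)cc2)cc1`: > 10000 nM, a limit

Compound 3 has no exact number on this read-out, only a limit: the limit of > 10000 nM in this assay, at which 1 of the 3 values shown sits. Compound 1 likewise gives only a limit: the limit of > 1000 nM in this assay, at which 1 of the 3 values shown sits. Compound 2 is the only one of the three with an exact value, 10000 nM.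

Compound 4 `c1ccc(-c2ccc(Cn3cncc3CNc3ccc(-c4cncs4)c(-c4ccccc4)c3)cc2)cc1` is derived from compound 3 by a single change: 1,3-thiazol-5-yl in place of phenyl on an aromatic carbon, ortho to a phenyl group and para to a large group (1,3-thiazol-5-yl in place of phenyl on an aromatic carbon).

Within the data shown here, one measured step bears on this change, as it also concerns the group at this place: a step that the two limits leave unreadable from compound 1 to compound 3. Among the measured compounds shown here, with both ends of that step being limits, it offers no size to carry over, and no other measured step tests this replacement. No step beyond the usual scatter is therefore expected in this assay, and no direction is favoured, although another limit would be no surprise.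

The expected change is a number no higher from compound 3 to compound 4 (the limit leaves the size open). Compound 4 is estimated at 10000 nM, with an expected range from 3000 nM to 30000 nM.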

Compound 4, half-maximal effective concentration: > 1000 nM
Compound 4 ended at the assay's limit (the forecaster's own chance of this, stated with the estimate: 60%); the middle value is on the limit's open side.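

Compound 4, like compound 1 and compound 3, has only a limit in this assay, and no step among these three compounds can be read. The limit for compound 4 is this one: the limit of > 1000 nM in this assay, at which 2 of the 4 values shown sit. The compounds shown leave open how large any change from 1,3-thiazol-5-yl in place of phenyl is on this read-out, and in which direction it runs.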